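Swapping the dichlorophenyl for a bromophenyl on the ethenyl arm

A few compounds are considered here, and "the series" means these few. Any claim that something is new, unique, unknown or untested is made for them only; others in the source may bear on it.

Of the compounds shown here, three sharing one core have been tested in an ADME assay on HaCaT cells (Homo sapiens) for cytotoxicity, read by MTT assay, with a stated time of 72 h; a lower number here means a stronger inhibitor, a higher number a weaker inhibitor. Compound 1 `NS(=O)(=O)c1cc(-c2nnc(Cn3cc(-c4ccccc4)nn3)o2)c(Cl)cc1SCc1ccccc1` gives 300000 nM, compound 2 `NS(=O)(=O)c1cc(-c2nnc(/C=C/c3cccc(Cl)c3)o2)c(Cl)cc1SCc1ccccc1` gives 16000 nM, and compound 3 `NS(=O)(=O)c1cc(-c2nnc(/C=C/c3c(Cl)cccc3Cl)o2)c(Cl)cc1SCc1ccccc1` gives 160000 nM, the second highest of the three numbers, within the scatter of compound 1 but well apart from compound 2. Compound 4 `NS(=O)(=O)c1cc(-c2nnc(/C=C/c3ccc(Br)cc3)o2)c(Cl)cc1SCc1ccccc1` differs from compound 3 by 4-bromophenyl in place of 2,6-dichlorophenyl on a double-bonded chain carbon bound to a double-bonded chain carbon. Among the compounds with values here, the only measured step at this position is a 10-fold higher number from compound 2 to compound 3 (1.00 log units; beyond the scatter), and the change to compound 4 partly reverses that step, so a modestly lower number is expected in this assay, namely a 3.2-fold lower number from compound 3 to compound 4 (0.51 log units; beyond the scatter). Compound 4 is therefore estimated at 50000 nM, with a range from 15000 nM to 160000 nM.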

Compound 4, half-maximal inhibitory concentration: 31000 nM
Compound 4: the middle estimate sits 1.6-fold (0.21 log units) above what was measured, within the range that was stated.
By their numbers in this assay, from the lowest: compounds 2 and 4 (each within the scatter of the next); then compounds 3 and 1 (each within the scatter of the next).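

In this assay, the high number of compound 3 does not carry over to every halogen-bearing phenyl on this ethenyl arm: 4-bromophenyl in place of 2,6-dichlorophenyl brings it down (a 5.2-fold lower number from compound 3 to compound 4 (0.71 log units; beyond the scatter)). Compound 4 cannot be told apart from the 3-chlorophenyl compound (a 1.9-fold higher number from compound 2 to compound 4 (0.29 log units; within the scatter)), and the ethenyl arm again stands well apart from the triazole-bearing arm (a 9.7-fold lower number from compound 1 to compound 4 (0.99 log units; beyond the scatter)). No measurement at hand explains these differences.

On these data alone, how an amine or a carboxylic acid on this phenyl ring, in place of the halogen, would behave remains open.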